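Swapping Fluoro for Methyl on the Triazole Aryl Group

The source may hold more compounds than are shown below. What is called first, only, known or untested is meant among the compounds shown, and "the series" means these compounds.

Of the compounds shown here, three sharing one core have been measured in a functional assay on HL-60 cells (Homo sapiens) for cytotoxicity, read by MTT assay, with a stated time of 4 days; a lower number here means a stronger inhibitor, a higher number a weaker inhibitor. Compound 1 `C=C1C(=O)[C@]23C[C@@]1(O)CC[C@H]2c1ccc(OS(=O)(=O)c2ccc(C)cc2)c(C)c1[C@@H]3Cn1cc(-c2ccccn2)nn1` gives 1810 nM. Compound 2 `C=C1C(=O)[C@]23C[C@@]1(O)CC[C@H]2c1ccc(O)c(C)c1[C@@H]3Cn1cc(-c2ccc(C)cc2)nn1`, which carries a free hydroxyl where the others carry a tosylate, gives 830 nM. Compound 3 `C=C1C(=O)[C@]23C[C@@]1(O)CC[C@H]2c1ccc(OS(=O)(=O)c2ccc(C)cc2)c(C)c1[C@@H]3Cn1cc(-c2ccc(F)cc2)nn1` gives 1290 nM; its number lies between the other two, yet all three fall within the usual scatter of one another, so no ranking can be read from them.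

The next compound, compound 4 `C=C1C(=O)[C@]23C[C@@]1(O)CC[C@H]2c1ccc(OS(=O)(=O)c2ccc(C)cc2)c(C)c1[C@@H]3Cn1cc(-c2ccc(C)cc2)nn1`, differs from compound 3 in one place: methyl in place of fluoro on an aromatic carbon. Going by the values given here, the one measured step that touches the same aryl group, a 1.4-fold lower number from compound 1 to compound 3 (0.15 log units; within the scatter), did not move the number beyond the scatter. Compound 2, which already carries the 4-methylphenyl group, shows a number within the scatter of compound 3 as well. The step to compound 4 is therefore expected to be small, a 1.1-fold lower number from compound 3 to compound 4 (0.03 log units; within the scatter), in no clear direction. Compound 4 is estimated to give 1200 nM in this assay, with a likely range from 500 nM to 3000 nM.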

Compound 4, half-maximal inhibitory concentration: 1110 nM
Estimate against measurement, compound 4: 1.1-fold (0.03 log units) above; measured number inside the range.
By their numbers in this assay, from the lowest: compounds 2, 4, 3 and 1 (each within the scatter of the next, the first and the last beyond it).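

In this assay, fluoro and methyl at this place on the aryl ring, para to a large group, cannot be told apart: the change gives a 1.2-fold lower number from compound 3 to compound 4 (0.07 log units; within the scatter) and stays within the scatter. Compound 4 also allows two single-place comparisons, and both stay within the scatter: a 1.6-fold lower number from compound 1 to compound 4 (0.21 log units; within the scatter) for 4-methylphenyl in place of pyridin-2-yl, and a 1.3-fold higher number from compound 2 to compound 4 (0.13 log units; within the scatter) for (4-methylphenyl)sulfonyl in place of hydrogen on the oxygen. No supporting measurement is available to explain why these changes leave the number within the scatter.

As far as these compounds go, it remains open whether an amine, a carboxylic acid or a longer chain at this place on the aryl ring would move the number beyond the scatter. From the compounds shown here alone, whether fluoro and methyl would also match with a free hydroxyl on the core is equally open.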